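Trifluoromethyl in place of bromo: working notes

The compounds below may be only part of what the source reports. "The series", "measured", "known", "first", "only" and "open" are said of these compounds alone.

Measured so far in an ADME assay on Jurkat cells (Homo sapiens) for cytotoxicity, read by MTT assay (a lower number here means a stronger inhibitor, a higher number a weaker inhibitor), as follows:
Compound 1 `O/N=C(\COc1cccc2ccccc12)c1ccc(F)cc1` gives > 50000 nM as a limit
Compound 2 `O/N=C(\COc1cccc2ccccc12)c1ccc(Cl)cc1` gives > 50000 nM as a limit
Compound 3 `O/N=C(\COc1cccc2ccccc12)c1ccc(Br)cc1` gives > 50000 nM as a limit

Compound 3 therefore has no number to stand on, only a limit. Among the compounds with values here, the whole series so far sits at the limit of > 50000 nM in this assay, at which 3 of the 3 values shown sit, and offers no measured value to work from. Compound 4 `O/N=C(\COc1cccc2ccccc12)c1ccc(C(F)(F)F)cc1` carries trifluoromethyl in place of bromo on an aromatic carbon and is otherwise unchanged from compound 3. The measured steps bearing on this change are a step that the two limits leave unreadable from compound 1 to compound 2 then a step that the two limits leave unreadable from compound 1 to compound 3 and a step that the two limits leave unreadable from compound 2 to compound 3 so no size can be carried over from them. In this assay no step beyond the scatter is expected, and no direction can be given, so the expected change is a number no higher from compound 3 to compound 4 (the limit leaves the size open) and nothing firmer. A report as a limit is the likeliest outcome for compound 4. For compound 4 the estimate is 50000 nM and 20000 nM to 100000 nM is the expected range.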

Compound 4, half-maximal inhibitory concentration: > 50000 nM
Compound 4 gave a limit, no number (the forecaster's own chance of this, stated with the estimate: 85%); the middle value sits exactly at the limit.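

In this assay, within the data shown here, compound 4 gives > 50000 nM as a limit and not a number, so no step from compound 1, compound 2 or compound 3 to compound 4 can be read: the limit of > 50000 nM in this assay, at which 4 of the 4 values shown sit. The compounds shown leave open whether any substituent at this place on the shared core changes the read-out.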